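The compounds below may be only part of what the source reports. "The series", "measured", "known", "first", "only" and "open" are said of these compounds alone.

Three compounds of the series have been run in a functional assay on HT-1080 cells (Homo sapiens), read by transwell migration, with a stated time of 24 h, tested at 10 uM; a lower number here means a stronger effect, a higher number a weaker effect of the compound at the concentration tested. For the measured compounds named here, compound 1 `CC(=O)OCc1ccc2oc(=O)c(C(=O)Sc3cccc(Cl)c3)cc2c1` gives 61.9% and compound 2 `CC(=O)OCc1ccc2oc(=O)c(C(=O)Nc3cccc(Cl)c3)cc2c1` gives 42.8%; the one measured step between them, a number 19.1 percentage points lower from compound 1 to compound 2 (beyond the scatter), concerns only the group on the carbonyl carbon. Compound 3 `CCC(=O)OCc1ccc2oc(=O)c(C(=O)Oc3cccc(Br)c3)cc2c1` gives 21.3%, the lowest of the three numbers, set apart from compound 2 and from compound 1 by gaps beyond the scatter.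

Compound 4 `CCCCC(=O)OCc1ccc2oc(=O)c(C(=O)Oc3cccc(Br)c3)cc2c1` has not yet been measured. It differs from compound 3 by ethyl in place of hydrogen on a saturated chain carbon, two bonds along the chain from a carbonyl carbon. Going by the values given here, no measured step touches this part of the molecule: the only step on record, a number 19.1 percentage points lower from compound 1 to compound 2 (beyond the scatter), alters the group on the carbonyl carbon and says nothing about the saturated chain. The expectation is therefore for no step beyond the scatter in this assay, a number 0.3 percentage points lower from compound 3 to compound 4 (within the scatter), with a wide range for lack of any guide. Compound 4 is estimated at 21%, between 8% and 36%.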

Compound 4, a percentage reported as activity, at one concentration (the size of the read-out at that concentration, not a potency): 32.3%
Estimate against measurement, compound 4: 11.3 percentage points below; the measured number falls inside the stated range.
By their numbers in this assay, from the lowest: compound 3; then compound 4; then compound 2; then compound 1.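

In this assay, the saturated chain proves responsive to change: ethyl in place of hydrogen, two bonds along the chain from a carbonyl carbon, gives a number 11 percentage points higher from compound 3 to compound 4 (beyond the scatter), so the added carbons weaken the effect at the concentration tested. For the compounds shown here, this is the first reading on this part of the molecule, as the earlier step concerned only the group on the carbonyl carbon, and it shows that the chain can shift the read-out as well. No available data bear on the reason for this step.

From the compounds shown here alone, with only propanoyl and butylcarbonyl compared directly, the trend along the chain remains unknown, and a longer chain, or one ending in an amine or a carboxylic acid, could continue or break it. Going by these compounds, it also remains open whether the same step holds with (3-chlorophenyl)amino on the carbonyl carbon.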